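The compounds below may be only part of what the source reports. "The series", "measured", "known", "first", "only" and "open" are said of these compounds alone.

Measured compounds:
- compound 1, `COc1ccc(-c2nc3ccccc3s2)cc1OC`: in a functional assay on MDA-MB-468 cells (Homo sapiens) for antiproliferative activity (a lower number here means a stronger inhibitor of growth, a higher number a weaker inhibitor of growth), compound 1 gives 530 nM
- compound 2, `COc1ccc(-c2nc3cc(F)ccc3s2)cc1`: compound 2 gives 330 nM
- compound 3, `COc1ccc(-c2nc3cc(F)ccc3s2)cc1F`: compound 3 gives 640 nM

The three measured compounds share a common arrangement and differ only in the pattern of small substituents. The values of compound 1, compound 2 and compound 3 all lie within the usual scatter of one another, so none of them can be singled out as the stronger or weaker growth inhibitor on this evidence. How the core of compound 1 differs from that of compound 2 is not broken down here.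

One structural change within the measured set is documented as a single step: from compound 2 to compound 3 the change is fluoro in place of hydrogen on an aromatic carbon
and it produced a 1.9-fold higher number from compound 2 to compound 3 (0.29 log units; within the scatter).

Compound 4, `COc1ccc(-c2nc3c(F)cccc3s2)cc1OC`, is not yet measured. It is related to compound 1 by fluoro in place of hydrogen on an aromatic carbon
Within the data shown here, this is the same kind of change as the one from compound 2 to compound 3, but not the same: there the fluoro entered a six-membered aromatic ring of carbon only, ortho to a methoxy group (2 heavy atoms) and meta to a large group, whereas here it enters a ring that is part of a fused or bridged system of two rings, ortho to a fused ring and meta to a fused ring.

Among the measured compounds shown here, because the only precedent, a 1.9-fold higher number from compound 2 to compound 3 (0.29 log units; within the scatter), stayed within the scatter, compound 4 is expected to show a 1.3-fold higher number from compound 1 to compound 4 (0.12 log units; within the scatter) in this assay relative to compound 1. The estimate for compound 4 is 700 nM, with a range from 300 nM to 1600 nM.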

Compound 4, concentration for 50% growth inhibition: 5 nM
The estimate for compound 4 lay 140-fold (2.15 log units) above the measured number; the whole stated range lies above it.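

In this assay, fluoro in place of hydrogen on an aromatic carbon of the core of compound 1, ortho to a fused ring and meta to a fused ring, gave a 110-fold lower number from compound 1 to compound 4 (2.03 log units; beyond the scatter), a large step. Set beside the one earlier example, the same kind of change did not carry over from one core to another with a similar result: the same change on two cores in this assay, a 1.9-fold higher number (0.29 log units; within the scatter) from compound 2 to compound 3 and a 110-fold lower number (2.03 log units; beyond the scatter) from compound 1 to compound 4, 210-fold (2.31 log units) apart, beyond the scatter of two such steps This shows that, in this series, the outcome of adding a fluoro cannot be read from one core and applied to another, but it does not show what sets the two steps apart, since they differ both in the core and in the ring that takes the fluoro, and there is only one step on each core.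

The compounds shown leave open whether the large step belongs to this place on the ring or depends on the rest of compound 1, including its two methoxy groups. They also leave open whether a chloro, a methyl or an amine on the same aromatic carbon would give a number like that of compound 4 or one like that of compound 1.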